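The source may hold more compounds than are shown below. What is called first, only, known or untested is meant among the compounds shown, and "the series" means these compounds.

Compound 1, `Cc1cc(C)n(CCOC2CC(=O)Nc3c2c(C)nn3-c2ncnc3nc[nH]c23)n1`, is the anchor of this account. Among the measured compounds shown here, in a functional assay on HEK293 cells for agonist activity at G-protein coupled receptor 39 (Homo sapiens), read by scintillation proximity assay and inositol phosphate accumulation, with a stated time of 75 min, in the presence of a further agent that is not named here (on this read-out higher numbers stand for an effect only at larger amounts of compound and lower numbers for an effect already at smaller amounts), compound 1 gives 16 nM, the lowest of the two numbers available; the only comparison is compound 2, `O=C1/C(=C/NCCCO)C(c2ccccc2)=NN1c1nc2ccccc2s1`, which in this assay gives 200 nM, a higher number that lies beyond the usual scatter. For the measured compounds named here, no pair of measured compounds that differ in a single place exists here, so no measured step can guide the next change. Compound 3, `Cc1nn(-c2ncnc3nc[nH]c23)c2c1C(c1ccc(F)cc1Cl)CC(=O)N2`, departs from compound 1 in one place: a group of 8 heavy atoms (6 carbon, 1 fluorine, 1 chlorine; one six-membered aromatic ring of carbon only) in place of a group of 10 heavy atoms (7 carbon, 2 nitrogen, 1 oxygen; one five-membered aromatic ring with 2 hetero atoms), on a saturated ring carbon. Compound 2 is too different in its whole make-up to say anything about that exchange. The size of the change, with the group that leaves carrying hydrogen-bond acceptors and the group that enters carrying none, suggests that some weakening is expected, though not necessarily one beyond the scatter; the expected step of a 3.1-fold higher number from compound 1 to compound 3 (0.49 log units; beyond the scatter) is therefore modest. Compound 3 is expected to give about 50 nM, within a range from 10 nM to 250 nM.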

Compound 3, half-maximal effective concentration: 9 nM
Beside the measured number, compound 3's estimate is 5.6-fold (0.74 log units) above it; measured number outside the range, below it.
By their numbers in this assay, from the lowest: compounds 3 and 1 (each within the scatter of the next); then compound 2.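

The saturated ring carbon, three ring bonds from the ring nitrogen, tolerates a replacement of the whole group: the step is a 1.8-fold lower number from compound 1 to compound 3 (0.25 log units; within the scatter) and so gives no measurable separation between the two groups. For this pair, then, the hydrogen-bond acceptors of the group that leaves are not needed to hold a number of this size, since 2-chloro-4-fluorophenyl, which carries none, reads alike. Nothing measured here explains why the two groups read alike.

Whether the chlorine and the fluorine each matter remains open, as the compounds shown offer no unsubstituted phenyl on this carbon to compare. Also open, as far as these compounds go, is how an amine, a carboxylic acid or a longer chain on the same carbon would read.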